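Removing the trifluoromethyl from the benzamide of compound 1

The compounds below may be only part of what the source reports. "The series", "measured", "known", "first", "only" and "open" are said of these compounds alone.

Compound 1 `COc1cc(-c2nn(-c3cccc(NC(=O)c4cccc(C(F)(F)F)c4)c3)cc2-c2ccncc2)ccc1Cl` is one of two compounds with numbers in a functional assay on OVCAR-3 cells (Homo sapiens) for inhibition, read by sulforhodamine B assay, with a stated time of 48 h; on this read-out higher numbers stand for weaker inhibition of growth and lower numbers for stronger inhibition of growth. In this assay compound 1 gives 1200 nM, the highest of the two numbers. Among the compounds with values here, its only neighbour, compound 2 `O=C(Nc1cccc(-n2cc(-c3ccncc3)c(-c3ccc(Cl)c(O)c3)n2)c1)Nc1cc(C(F)(F)F)cc(C(F)(F)F)c1`, carries a urea in place of the amide and a hydroxyl in place of the methoxy; in this assay compound 2 gives 395 nM, a gap from compound 1 that lies beyond the scatter.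

Compound 3 `COc1cc(-c2nn(-c3cccc(NC(=O)c4ccccc4)c3)cc2-c2ccncc2)ccc1Cl` differs from compound 1 in one place: hydrogen in place of trifluoromethyl on an aromatic carbon. The change sits on the benzoyl ring of the amide, on an aromatic carbon of a six-membered aromatic ring of carbon only, meta to a large group.

Within the data shown here, no pair of measured compounds shows this change, so the account has no step to lean on. The group that leaves is all that distinguishes the benzoyl of compound 1 from the plain benzoyl of compound 3, and the author expects the loss to weaken growth inhibition by a modest amount, a step from compound 1 to compound 3 of a 1.8-fold higher number from compound 1 to compound 3 (0.26 log units; within the scatter). Compound 3 is accordingly estimated at 2200 nM, with a range from 800 nM to 6000 nM.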

Compound 3, concentration for 50% growth inhibition: 334 nM
Estimate against measurement, compound 3: 6.6-fold (0.82 log units) above, and the stated range ends above it.
By their numbers in this assay, from the lowest: compounds 3 and 2 (each within the scatter of the next); then compound 1.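

Within the data shown here, with hydrogen in place of trifluoromethyl on the benzoyl ring, this assay gives a 3.6-fold lower number from compound 1 to compound 3 (0.56 log units; beyond the scatter), the first step in this set that can be read at a single place, since compound 1 and compound 2 differ in more than one. It shows that, on this core, trifluoromethyl on an aromatic carbon meta to a large group is not needed for growth inhibition: the plain benzoyl of compound 3 inhibits more strongly than the 3-(trifluoromethyl)phenyl carbonyl of compound 1. No measurement shown explains why the loss of this group strengthens inhibition.

The compounds shown leave open whether a smaller group on the same carbon, such as a methyl, a chlorine or an amine, would fall with compound 3 or with compound 1, and whether a carboxylic acid there would be tolerated at all. They also leave open whether the same change would bring a similar step on the urea of compound 2, since this single pair speaks only for the amide with the methoxy in place.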